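This account rests on a few compounds, and the source may have more. Where it says the series, first, only, none or still open, it means among the compounds named here.

Working notes on the series.

Going by the values given here, compound 2 `CC1=C(c2cccc(C#N)c2)C(c2ccc(OC[C@H](C)N3CC[C@@H](C)C3)cc2)Oc2ccc(O)cc21` is the weakest of the three measured members. In a functional assay on MCF7 cells (Homo sapiens) for antiproliferative activity, read by CellTiter-Glo, with a stated time of 5 days (on this read-out higher numbers stand for weaker inhibition and lower numbers for stronger inhibition), compound 2 gives 2.6 nM, the highest number of the three. Compound 1 `CC1=C(c2cccc(O)c2)C(c2ccc(OC[C@H](C)N3CC[C@@H](C)C3)cc2)Oc2cc(O)ccc21` gives 0.3 nM in this assay, a lower number than compound 2 by a margin beyond the scatter. Compound 3 `CC1=C(c2cccc(O)c2)C(c2ccc(OC[C@H](C)N3CCCCC3)cc2)Oc2ccc(O)cc21` gives 0.1 nM in this assay, further still below compound 2 and likewise beyond the scatter. Among the compounds with values here, no single-change step links any two of the measured compounds, so the comparison rests on the values themselves; compounds 1 and 3 both carry a hydroxyl-bearing phenyl where compound 2 carries a nitrile-bearing one, and both sit well below it.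

Compound 4 `CC1=C(c2ccc(O)cc2)C(c2ccc(OC[C@H](C)N3CC[C@@H](C)C3)cc2)Oc2ccc(O)cc21` has not yet been measured. It differs from compound 2 by 4-hydroxyphenyl in place of 3-cyanophenyl on a double-bonded ring carbon. The hydroxyl enters on a ring carbon where compound 2 has the nitrile, although not at the same ring carbon as in compounds 1 and 3, so those two give only an indirect guide.

The step from compound 2 to compound 4 is expected to be downward and beyond the scatter, a 5.2-fold lower number from compound 2 to compound 4 (0.72 log units; beyond the scatter), because compound 1 gives 0.3 nM and compound 3 gives 0.1 nM with hydroxyl-bearing phenyls. For compound 4 the estimate in this assay is 0.5 nM, in the range 0.1 nM to 2.5 nM.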

Compound 4, half-maximal inhibitory concentration: 0.1 nM
Compound 4: middle estimate off by 5.0-fold (0.70 log units), on the high side; the range from low to high includes it.
By their numbers in this assay, from the lowest: compounds 3 and 4 (each within the scatter of the next); then compound 1; then compound 2.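

Going by these compounds alone, this is the first single-change step. With the rest of compound 2 held constant, 4-hydroxyphenyl in place of 3-cyanophenyl on a double-bonded ring carbon gives, in this assay, a 26-fold lower number from compound 2 to compound 4 (1.41 log units; beyond the scatter) and so shows that the read-out is highly sensitive to the group at this position, which compounds 1 and 3 could only suggest, as each differs from compound 2 in more than one place. No measured evidence here accounts for the size of this step.

The change replaces the nitrile with a hydroxyl and also alters where the substituent sits on the phenyl ring, so the compounds shown do not separate the contribution of the group from that of its ring position. As far as these compounds go, it also remains open how the read-out at this position would respond to a phenyl bearing an amine or a carboxylic acid, or to a longer chain carrying the hydroxyl, with the rest of compound 4 unchanged.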